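The compounds below may be only part of what the source reports. "The series", "measured", "known", "first", "only" and "open" are said of these compounds alone.

Working notes on the series. Compound 1 `CC[C@H](C)n1c(=O)[nH]c2ncc(Br)nc21` gives 0.3 in an ADME assay on microsomes from liver (Rattus norvegicus), read by LC-MS, with a stated time of 90 min; on this read-out lower numbers stand for lower hepatic extraction and higher numbers for higher hepatic extraction. Compound 2 `CC(C)n1c(=O)[nH]c2ncc(Br)nc21` has "not determined" (no result reported) in this assay, so no number is available for it. Compound 3 `CCC(CC)n1c(=O)[nH]c2ncc(C)nc21` gives 0.7 in this assay, the higher of the two numbers in hand; compound 1 sits lower by a margin beyond the usual scatter.

Compound 4 `C=Cc1cnc2[nH]c(=O)n(C(CC)CC)c2n1` differs from compound 3 by vinyl in place of methyl on an aromatic carbon. Going by the values given here, no measured pair in this set shows that change, so its effect is unknown here. The step a number 0.050 higher from compound 3 to compound 4 (within the scatter) is expected to be small, at most a slight rise and possibly none beyond the scatter. Compound 4 is estimated at 0.75, with a range from 0.55 to 0.9.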

Compound 4, hepatic extraction ratio: > 0.7
Compound 4: only a limit was reported; the forecaster's own chance of this, stated with the estimate: 0%; the middle value is on the limit's open side.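

Vinyl in place of methyl on an aromatic carbon gives a number no lower from compound 3 to compound 4 (the limit leaves the size open) in this assay, the first step readable at this position. Compound 4 has > 0.7 in this assay, and this is a limit, not a number. With vinyl, this position reaches a limit of the read-out, which neither earlier number did: the limit of > 0.7 in this assay, at which 1 of the 4 values shown sits.

On these data alone, how far compound 4 lies past that limit stays open, so the size of the step cannot be read. As far as these compounds go, whether an amine, a methoxy group or a longer chain on this aromatic carbon would also read at the limit stays open too.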